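The source may hold more compounds than are shown below. What is called first, only, known or untested is meant among the compounds shown, and "the series" means these compounds.

Working notes on the series. Of the compounds shown here, two share a core and have been measured in a functional assay on the whole organism (strain Sprague-Dawley) for inhibition, with Rattus norvegicus as the target, read by paw edema, with stated times of 1 h and 3 h, at a dose of 50 mg/kg by the oral route; on this read-out higher numbers stand for more inhibition at the one dose given (going by the name of the read-out) and lower numbers for less inhibition. Compound 1 `CN(C)c1nc(N)sc1C(=O)c1cnc2ccccn12` gives 32%. Compound 2 `Cc1ccc2ncc(C(=O)c3sc(N)nc3N(C)C)n2c1` gives 23%. For the measured compounds named here, the only step so far, a number 9 percentage points lower from compound 1 to compound 2 (within the scatter), is a methyl in place of hydrogen on an aromatic carbon, and it does not reach beyond the scatter. On the two numbers available compound 2 holds the lower number, but its gap to compound 1 is within the scatter, so no order between them can be read.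

Compound 3 `Cc1ccc2ncc(C(=O)c3sc(N)nc3C)n2c1` is not yet measured. It differs from compound 2 by methyl in place of dimethylamino on an aromatic carbon. Going by the values given here, no measured step bears on this change: the one step recorded concerns a methyl on an aromatic carbon of the core, not the group that is exchanged here, and the exchange of a dimethylamino for a methyl has not been tested anywhere. The expectation therefore rests on compound 2 alone. The step expected is a number 1 percentage points lower from compound 2 to compound 3 (within the scatter), no movement beyond the scatter, with a wide range. Compound 3 is estimated at 22%, between 5% and 40%.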

Compound 3, a percentage reported as inhibition, in the whole organism at one dose (the size of the read-out at that dose, not a potency): 33%
Estimate against measurement, compound 3: 11 percentage points below; low and high end bracket the measured number.
By their numbers in this assay, from the lowest: compounds 2, 1 and 3 (each within the scatter of the next).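

In this assay, for the compounds shown here, the exchange of dimethylamino for methyl, on the aromatic carbon next to the ring nitrogen of the five-membered aromatic ring with 1 nitrogen and 1 sulfur, gives a number 10 percentage points higher from compound 2 to compound 3 (within the scatter) and is the first reading at this place, as the earlier step concerned a different aromatic carbon. Dimethylamino, with 3 heavy atoms and 1 hydrogen-bond acceptor, gives way here to methyl, with 1 heavy atom and 0 hydrogen-bond acceptors, without a movement beyond the scatter, so the dimethylamino group is not shown to be required for the inhibition seen at this one dose. No measurement on hand bears on the reason for this result.

Still open, going by these compounds, is whether a longer chain such as ethyl, a primary amine or a carboxylic acid at this same place would move the number beyond the scatter. Also open, on these data alone, is whether a hydrogen in place of the methyl on the other aromatic carbon would change the reading when methyl, rather than dimethylamino, occupies this place.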